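Shortening the chain of compound 1

The source may report more compounds than this note shows. Statements on the series, on what has been measured and on what is new or still open speak of the compounds shown alone.

- Compound 1 `CC(C)c1cc(C(=O)N(C)c2ccc(NC(=O)CCCCCCCCC(=O)NO)cc2)c(O)cc1O` gives (1080 nM)
- Compound 2 `CC(C)c1cc(C(=O)N(c2ccc(NC(=O)CCCCCCC(=O)NO)cc2)C(C)C)c(O)cc1O` gives a limit (> 10000 nM)
- Compound 3 `CC(C)c1cc(C(=O)Nc2ccccc2NC(=O)CCCCCCC(=O)NO)c(O)cc1O` gives a limit (> 10000 nM)

Going by the values given here, in a functional assay on A549 cells (Homo sapiens) for inhibition, read by sulforhodamine B assay, with a stated time of 48 h (on this read-out higher numbers stand for weaker inhibition of growth and lower numbers for stronger inhibition of growth), compound 1 gives 1080 nM as the only true number here. Compounds 2 and 3 give no number, only (the limit of > 10000 nM in this assay, at which 2 of the 3 values shown sit).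

Compound 4 `CC(C)c1cc(C(=O)N(C)c2ccc(NC(=O)CCCCCC(=O)NO)cc2)c(O)cc1O` keeps the core of compound 1 with one change (hydroxycarbamoyl in place of 3-(hydroxycarbamoyl)propyl on a saturated chain carbon, five bonds along the chain from a carbonyl carbon): hydroxycarbamoyl in place of 3-(hydroxycarbamoyl)propyl on a saturated chain carbon, five bonds along the chain from a carbonyl carbon.

Among the compounds with values here, no measured pair shows this change alone, so its size is a judgement. In this assay a moderate step toward weaker inhibition is expected (a 4.6-fold higher number from compound 1 to compound 4 (0.67 log units; beyond the scatter)), starting from compound 1 at 1080 nM. For compound 4 the estimated value is 5000 nM (range 1500 nM to 17000 nM).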

Compound 4, concentration for 50% growth inhibition: 2830 nM
For compound 4 the middle estimate is 1.8-fold (0.25 log units) above the measured one, within the range that was stated.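

Shortening the chain, read as 6-(hydroxycarbamoyl)hexyl to 3-(hydroxycarbamoyl)propyl, gives the first direct comparison at this position: in this assay there is a 2.6-fold higher number from compound 1 to compound 4 (0.42 log units; beyond the scatter), a modest weakening of growth inhibition. The shorter chain still gives a true number rather than a limit, with compound 4 at 2830 nM. Nothing shown here explains why this step has its size.

Going by these compounds alone, two chain lengths give only one step, so whether a chain longer than that of compound 1 would strengthen or weaken inhibition stays open. Also open, on these data alone, is how a carboxylic acid in place of the hydroxycarbamoyl end would behave.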